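Oxalamide variants on a fluorophenoxyacetic acid core

The compounds below may be only part of what the source reports. "The series", "measured", "known", "first", "only" and "open" are said of these compounds alone.

The series is read in a functional assay on CHO cells for agonist activity at Free fatty acid receptor 1 (Homo sapiens), read by FLIPR, tested at 300 nM; on this read-out higher numbers stand for a stronger effect at the one concentration tested and lower numbers for a weaker effect. Compound 1 `Cc1cc(OCCCS(C)(=O)=O)cc(C)c1-c1cccc(COc2ccc(OCC(=O)O)c(F)c2)c1` gives 67.3%. Compound 2 `Cc1cccc(NC(=O)C(=O)Nc2ccc(OCC(=O)O)c(F)c2)c1` gives 36.3%, the lower of the two numbers recorded; the gap between compound 1 and compound 2 lies beyond the scatter of the method, yet with no single-point change connecting them, nothing more can be drawn from the pair than the two values themselves.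

The step under study leads from compound 2 to compound 3 `COc1ccccc1NC(=O)C(=O)Nc1ccc(OCC(=O)O)c(F)c1`, a compound not yet measured. The change is 2-methoxyphenyl in place of 3-methylphenyl on an amide-type nitrogen. Within the data shown here, no measured pair in the set mirrors this exchange, so the expected size of the step in this assay rests on compound 2 alone. The step from compound 2 to compound 3 is expected to be small, a number 4.3 percentage points lower from compound 2 to compound 3 (within the scatter), not clearly beyond the scatter in either direction. Compound 3 is estimated at 32%, in the range from 10% to 55%.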

Compound 3, a percentage reported as activity, at one concentration (the size of the read-out at that concentration, not a potency): 19.9%
Estimate against measurement, compound 3: 12.1 percentage points above; the range from low to high includes it.
By their numbers in this assay, from the lowest: compound 3; then compound 2; then compound 1.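

Among these compounds, this is the first change at a single place that can be read in this assay. Putting 2-methoxyphenyl in place of 3-methylphenyl on the amide-type nitrogen gives a number 16.4 percentage points lower from compound 2 to compound 3 (beyond the scatter), so the read-out at the one concentration tested responds to the aryl group at this nitrogen, and here the entering group, with its added oxygen and hydrogen-bond acceptor, goes with the lower number. Nothing in the data given accounts for this drop.

The step changes both the substituent and its numbered place on the phenyl ring, and the compounds shown do not separate these two changes. On these data alone, whether a chlorine atom, an amine or a longer alkoxy chain on that ring would raise or lower the number remains open.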